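Hexyl in place of bromo on the sulfonamide aryl ring

The source may report more compounds than this note shows. Statements on the series, on what has been measured and on what is new or still open speak of the compounds shown alone.

Measured compounds: compound 1 `CC(=O)Nc1nc(-c2cccc(NS(=O)(=O)c3ccc(Br)cc3)c2)cs1`, "not active" (no number reported); compound 2 `CC(=O)Nc1nc(-c2cccc(NS(=O)(=O)c3ccc(C#C[Si](C)(C)C)cc3)c2)cs1`, 94.3%; compound 3 `CC(=O)Nc1nc(-c2cccc(NS(=O)(=O)c3cccc(C#C[Si](C)(C)C)c3)c2)cs1`, 61.6%.

In a functional assay on A-375 cells (Homo sapiens) for antiproliferative activity, read by trypan blue exclusion, with a stated time of 48 h, tested at 1 uM (on this read-out higher numbers stand for a weaker effect at the one concentration tested and lower numbers for a stronger effect), compound 1 is reported as "not active" (no number reported), so it gives no number to stand on. Compound 2 gives 94.3% and compound 3 gives 61.6% in this assay; these two values show what the shared core reaches when a different group sits on that ring. Compound 4 `CCCCCCc1ccc(S(=O)(=O)Nc2cccc(-c3csc(NC(C)=O)n3)c2)cc1` differs from compound 1 by hexyl in place of bromo on an aromatic carbon. Going by the values given here, no measured step covers this change, and compound 1 has no number, so the size of the step in this assay cannot be set from the data. Compound 4 is expected to give about 75%, within a range from 40% to 100%.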

Compound 4, a percentage reported as activity, at one concentration (the size of the read-out at that concentration, not a potency): 49.9%
Beside the measured number, compound 4's estimate is 25.1 percentage points above it; measured number inside the range.
By their numbers in this assay, from the lowest: compound 4; then compound 3; then compound 2.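

With the same count of heavy atoms on this aromatic carbon, replacing the silicon-bearing group with hexyl gives a number 44.4 percentage points lower from compound 2 to compound 4 (beyond the scatter) in this assay, so the read-out at this position depends on which group sits there and not only on its heavy-atom count. The step from bromo to hexyl itself cannot be read, as compound 1 has no number. No measurement shown here accounts for the difference. From the compounds shown here alone, whether a shorter chain such as butyl, a longer chain such as octyl, or an amine at this position would shift the read-out further remains open.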